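The compounds below may be only part of what the source reports. "The series", "measured", "known", "first", "only" and "open" are said of these compounds alone.

Three compounds were measured in a functional assay on cells (Neutrophil, Homo sapiens) for inhibition, read by WST assay, with a stated time of 20 min; on this read-out lower numbers stand for stronger inhibition and higher numbers for weaker inhibition:

- compound 1 `CNC1=C(Cl)C(=O)c2cccnc2C1=O`: 41100 nM
- compound 2 `CNC1=C(Sc2ccccc2)C(=O)c2ncccc2C1=O`: > 150000 nM, a limit of the assay
- compound 3 `CSC1=C(N)C(=O)c2cccnc2C1=O`: > 150000 nM, a limit of the assay

Compound 1 is the only one of the three that gives a number in this assay; the other two sit at the limit of > 150000 nM in this assay, at which 2 of the 3 values shown sit, so compound 1 is the sole anchor for what follows. Compound 2 gives only a limit in this assay. Compound 3 likewise gives only a limit in this assay.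

Compound 4 `CNC1=C([S+](C)[O-])C(=O)c2cccnc2C1=O` has not yet been measured. It differs from compound 1 by a group of 3 heavy atoms (1 carbon, 1 oxygen, 1 sulfur; no ring) in place of one chlorine atom, on a double-bonded ring carbon, next to the ring atom that bears a methylamino group. Among the compounds with values here, no measured pair in this set shares that change, so the size of the step cannot be read from the data; the account expects at most a modest step toward weaker inhibition in this assay, possibly none beyond the usual scatter, and a real chance that compound 4 returns only a limit. On that basis compound 4 is estimated at 60000 nM in this assay, within 15000 nM to 150000 nM. The expected step of a 1.5-fold higher number from compound 1 to compound 4 (0.16 log units; within the scatter) is small.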

Compound 4, half-maximal inhibitory concentration: > 200000 nM
Compound 4: a limit, no number; the forecaster's own chance of this, stated with the estimate: 40%; middle value at least 3.3-fold (0.52 log units) away from the limit.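

Within the data shown here, compound 1 and compound 4 are the first pair here that differ in one place, so the change on the double-bonded ring carbon next to the ring atom that bears a methylamino group can now be read: in this assay it gives an at least 4.8-fold higher number from compound 1 to compound 4 (0.68 log units; beyond the scatter) and thus a real loss. At this position, the chloro group cannot be exchanged for the group of 3 heavy atoms (1 carbon, 1 oxygen, 1 sulfur; no ring) while keeping a measurable number, so the chlorine-bearing compound 1 remains the only anchor. Compound 4 gives only a limit and no number, so the step is a lower bound: the limit of > 200000 nM in this assay, at which 1 of the 4 values shown sits.

The compounds shown leave open whether the loss comes from removing the chlorine or from the group that enters, as one pair cannot separate the two, and how far the true value of compound 4 lies beyond its limit. They also leave open whether bromine, a methyl group or a morpholine ring at this position would keep a number in this assay and how such a compound would compare with compound 1.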